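The compounds below may be only part of what the source reports. "The series", "measured", "known", "first", "only" and "open" are said of these compounds alone.

Working notes on the urea series, a functional assay on cells (Mus musculus) for antiproliferative activity, read by sulforhodamine B assay, with a stated time of 5 days; a lower number here means a stronger inhibitor, a higher number a weaker inhibitor.

Of the compounds shown here, three have numbers so far. Compound 2 `O=C(Nc1cc(C(F)(F)F)cc(C(F)(F)F)c1)Nc1ncccc1O` gives 14800 nM in this assay. Compound 3 `O=C(Nc1ccc(Cl)c(C(F)(F)F)c1)Nc1ncccc1O` gives 15400 nM in this assay, and the two values sit within the scatter of each other, so no order between compound 2 and compound 3 can be drawn. For the measured compounds named here, compound 1 `Cc1ccc(NC(=O)Nc2ccc(Cl)c(C(F)(F)F)c2)cc1O` gives only a limit of the assay, > 20000 nM, and not a number; this is the one value at the limit noted in the limit of > 20000 nM in this assay, at which 1 of the 3 values shown sits. Compound 4 `Cc1ccc(NC(=O)Nc2cc(C(F)(F)F)cc(C(F)(F)F)c2)cc1O` is not yet measured in this assay.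

The change from compound 2 to compound 4 is 3-hydroxy-4-methylphenyl in place of 3-hydroxypyridin-2-yl on an amide-type nitrogen. Going by the values given here, no step between two measured compounds is available for this change, so its size can only be guessed. Compound 3 gives a number, and compound 1 carries the 3-hydroxy-4-methylphenyl group and gives only a limit. Compound 4 is therefore expected to be weaker, with a step of a 1.9-fold higher number from compound 2 to compound 4 (0.28 log units; within the scatter) to an estimate of 28000 nM, within a range from 10000 nM to 80000 nM, and with a fair chance that only a limit is reported.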

Compound 4, half-maximal inhibitory concentration: 15700 nM
Compound 4: middle estimate off by 1.8-fold (0.25 log units), on the high side; low and high end bracket the measured number.
By their numbers in this assay, from the lowest: compounds 2, 3 and 4 (each within the scatter of the next). At a limit, above all of these: compound 1.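

In this assay, for the compounds shown here, 3-hydroxy-4-methylphenyl in place of 3-hydroxypyridin-2-yl on an amide-type nitrogen gives a 1.1-fold higher number from compound 2 to compound 4 (0.03 log units; within the scatter), the first reading of this change between two numbers. With the rest of compound 2 held fixed, the carbon-only ring gives a number as the ring with one hetero atom does, and the two cannot be told apart at this place. Compound 1, which carries the same 3-hydroxy-4-methylphenyl group, remains a limit of the assay and not a number: the limit of > 20000 nM in this assay, at which 1 of the 4 values shown sits.

The same change on the other side of the urea, from compound 3 to compound 1, cannot be read as a step. On these data alone, whether an amine or a carboxylic acid in place of the hydroxy group would give a step beyond the scatter remains open.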